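Estimating Cytotoxicity After a Fluorine Enters the Aryl Group

The source may hold more compounds than are shown below. What is called first, only, known or untested is meant among the compounds shown, and "the series" means these compounds.

compound 1 `COc1nc(-c2cccc(Cl)c2)ccc1[C@@H](c1ccccc1)[C@@](O)(CCN(C)C)c1cccc2ccccc12`: "nd" (no result reported)
compound 2 `COc1nc(-c2ccsc2)ccc1[C@@H](c1ccccc1)[C@@](O)(CCN(C)C)c1cccc2ccccc12`: > 64 ug/mL
compound 3 `COc1nc(-c2ccc(OC(F)(F)F)cc2)ccc1[C@@H](c1ccccc1)[C@@](O)(CCN(C)C)c1cccc2ccccc12`: > 64 ug/mL

Three compounds sharing one core were examined in a toxicity assay on HeLa cells (Homo sapiens) for cytotoxicity; a lower number here means that less compound is tolerated, a higher number that more compound is tolerated. Compound 1 has no result of its own in this assay; it gives "nd" (no result reported). Compound 2 gives > 64 ug/mL, which is a limit of the assay and not a number. Compound 3 likewise gives > 64 ug/mL, also a limit. Among the measured compounds shown here, the one step among measured compounds, a step that the two limits leave unreadable from compound 2 to compound 3, is therefore unreadable, as both ends sit at the limit of > 64 ug/mL in this assay, at which 2 of the 3 values shown sit.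

Compound 4 `COc1nc(-c2ccc(Cl)c(F)c2)ccc1[C@@H](c1ccccc1)[C@@](O)(CCN(C)C)c1cccc2ccccc12` differs from compound 1 by 4-chloro-3-fluorophenyl in place of 3-chlorophenyl on an aromatic carbon. For the measured compounds named here, no measured step bears directly on this change, and compound 1 itself offers no number to start from. What the data show is only that two of the three values sit at the same limit, so nothing beyond the scatter can be expected in either direction. Compound 4 is estimated at 64 ug/mL, with a range from 32 ug/mL to 128 ug/mL.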

Compound 4, half-maximal cytotoxic concentration: > 64 ug/mL
Compound 4 gave a limit, no number; the forecaster's own chance of this, stated with the estimate: 75%; the middle value sits exactly at the limit.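

In this assay compound 4 gives > 64 ug/mL, which is a limit and not a number. Its steps to compound 2 and compound 3 therefore cannot be read, and no new step emerges: the limit of > 64 ug/mL in this assay, at which 3 of the 4 values shown sit.

The compounds shown leave open how much of compound 2, compound 3 or compound 4 the cells would tolerate, and where compound 1 stands.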